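The source may report more compounds than this note shows. Statements on the series, on what has been measured and on what is new or still open speak of the compounds shown alone.

Compound 1 `O=C(NCCCCc1ccccc1)n1c(=O)oc2ccccc21` gives 64 nM in an assay on HEK293 cells for inhibition of acid ceramidase (Homo sapiens), with a stated time of 10 min; a lower number here means a stronger inhibitor, a higher number a weaker inhibitor. Adding a group to its fused ring lowers the number in both measured cases: compound 2 `O=C(NCCCCc1ccccc1)n1c(=O)oc2cc([N+](=O)[O-])ccc21` gives 3 nM, and compound 3 `O=C(NCCCCc1ccccc1)n1c(=O)oc2c(Br)cccc21` gives 18 nM. Among these three, compound 2 stands lowest, with a 21-fold lower number from compound 1 to compound 2 (1.33 log units; beyond the scatter) and, for the other substituted compound, a 3.6-fold lower number from compound 1 to compound 3 (0.55 log units; beyond the scatter); the gap from compound 2 to compound 3 is also beyond the scatter.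

Compound 4 `O=C(NCCCCc1ccccc1)n1c(=O)oc2cc(-c3ccc(F)cc3)ccc21` differs from compound 2 in one place: 4-fluorophenyl in place of nitro on an aromatic carbon. Among the compounds with values here, no measured step swaps one substituent for another at this carbon, so the two steps from compound 1 are the only guide, and both point the same way: a substituent on the fused ring lowers the number relative to the bare ring, nitro strongly, bromo modestly. Compound 4 keeps a substituent at the same place but loses the nitro group, which carried the largest lowering seen here. As far as these compounds go, a larger, acceptor-free group is untested. The number for compound 4 is therefore expected to rise somewhat from compound 2, as a 5.0-fold higher number from compound 2 to compound 4 (0.70 log units; beyond the scatter), remaining below compound 1 but with a wide range. Compound 4 is estimated at 15 nM, between 4 nM and 60 nM.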

Compound 4, half-maximal inhibitory concentration: 79 nM
Compound 4: middle estimate off by 5.3-fold (0.72 log units), on the low side; measured number above the stated range.
By their numbers in this assay, from the lowest: compound 2; then compound 3; then compounds 1 and 4 (each within the scatter of the next).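

In this assay, putting 4-fluorophenyl in place of nitro on this aromatic carbon gives a 26-fold higher number from compound 2 to compound 4 (1.42 log units; beyond the scatter), while putting it in place of hydrogen gives a 1.2-fold higher number from compound 1 to compound 4 (0.09 log units; within the scatter). Within the data shown here, the earlier steps showed only that adding a group lowered the number, but compound 4 goes against that pattern: it carries a group at this carbon, yet its number cannot be told apart from that of compound 1, so the low number of compound 2 comes with nitro and not with just any substituent here. Nothing available explains why these two groups differ so widely at this carbon.

As far as these compounds go, whether a nitrile, an amine or a methyl ester at this carbon would give a number like that of compound 2 or like that of compound 1 remains open, as does whether plain phenyl would behave differently from 4-fluorophenyl. Among these compounds, also open is whether nitro would give a similar drop on the other aromatic carbons of the shared core, or with a shorter or longer chain in place of the one these compounds share.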